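Urea aryl swap in the amidoxime series

The source may report more compounds than this note shows. Statements on the series, on what has been measured and on what is new or still open speak of the compounds shown alone.

Compound 1 `CCCCNC(=O)Nc1cc(/C(=N/O)Nc2ccc(F)c(Br)c2)ccc1N(CC(C)C)CC(C)C` carries a butyl group on the urea nitrogen. In an assay on isolated protein for inhibition of Indoleamine 2,3-dioxygenase 1 (Homo sapiens) (on this read-out higher numbers stand for weaker inhibition and lower numbers for stronger inhibition), compound 1 gives only a limit, > 3000 nM, not a number. Going by the values given here, compound 2 `Cc1ccc(NC(=O)Nc2cc(/C(=N/O)Nc3ccc(F)c(Br)c3)ccc2N(CC(C)C)CC(C)C)cc1` carries 4-methylphenyl on that nitrogen, and in this assay compound 2 gives 2300 nM, the only number in the set. Compound 1 supplies the remaining value, a limit (the limit of > 3000 nM in this assay, at which 1 of the 2 values shown sits). The step of an at least 1.3-fold lower number from compound 1 to compound 2 (0.11 log units; that floor lies within the scatter) is therefore a floor rather than a measured size.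

Compound 3 `CC(C)CN(CC(C)C)c1ccc(/C(=N/O)Nc2ccc(F)c(Br)c2)cc1NC(=O)Nc1cncnc1` differs from compound 2 by pyrimidin-5-yl in place of 4-methylphenyl on an amide-type nitrogen. Among the compounds with values here, the one measured step concerns a different exchange, butyl for 4-methylphenyl, and is only a floor; no measured step here involves a pyrimidin-5-yl. The expectation in this assay is for no step beyond the scatter, with a fair chance that compound 3 again returns only a limit. Compound 3 is estimated at 3000 nM in this assay, between 1000 nM and 9000 nM. The expected step is a 1.3-fold higher number from compound 2 to compound 3 (0.12 log units; within the scatter).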

Compound 3, half-maximal inhibitory concentration: > 3000 nM
Compound 3 ended at the assay's limit (the forecaster's own chance of this, stated with the estimate: 40%); the middle value sits exactly at the limit.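

On the amide-type nitrogen, pyrimidin-5-yl in place of 4-methylphenyl gives an at least 1.3-fold higher number from compound 2 to compound 3 (0.11 log units; that floor lies within the scatter), so neither a loss nor a gain is established in this assay. Compound 3 gives a limit, not a number. The step from compound 1 to compound 3 cannot be read, and compound 2 remains the only compound with a number at this position, while the limit now holds most of the set: the limit of > 3000 nM in this assay, at which 2 of the 3 values shown sit.

Open, going by these compounds, is whether pyridin-3-yl, 4-carboxyphenyl or 4-(dimethylamino)phenyl on this nitrogen would give a lower number than compound 2 does. Also open, on these data alone, is how much of the reading of compound 2 depends on its methyl group, a question that plain phenyl or 4-chlorophenyl at the same place would address.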